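The source may report more compounds than this note shows. Statements on the series, on what has been measured and on what is new or still open speak of the compounds shown alone.

Measured compounds:
- Compound 1 `Cc1ccc(S(=O)(=O)NCc2cn(C[C@H](O)[C@H]3OC(=O)C(OCc4ccccc4)=C3OCc3ccccc3)nn2)cc1`, in a functional assay on A549 cells (Homo sapiens) for antiproliferative activity, read by MTT assay, with a stated time of 72 h (on this read-out higher numbers stand for weaker inhibition and lower numbers for stronger inhibition), compound 1 gives 16800 nM.
- Compound 2 `C[Si](C)(C)c1cn(C[C@H](O)[C@H]2OC(=O)C(OCc3ccccc3)=C2OCc2ccccc2)nn1`, in this assay compound 2 gives 19200 nM.
- Compound 3 `COc1ccc(-c2cn(C[C@H](O)[C@H]3OC(=O)C(OCc4ccccc4)=C3OCc3ccccc3)nn2)cc1`, in this assay compound 3 gives 28300 nM.

All three compounds share the same core and differ only in the group carried on one aromatic carbon of the five-membered ring with three nitrogens. On the numbers shown, the value of compound 3 is the largest of the three, but the step of a 1.5-fold higher number from compound 2 to compound 3 (0.17 log units; within the scatter) and the step of a 1.7-fold higher number from compound 1 to compound 3 (0.23 log units; within the scatter) are both within the scatter, as is the step of a 1.1-fold higher number from compound 1 to compound 2 (0.06 log units; within the scatter), so the three compounds cannot be told apart in this assay.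

Compound 4 `O=C1O[C@H]([C@@H](O)Cn2cc(C3CC3)nn2)C(OCc2ccccc2)=C1OCc1ccccc1` is not yet measured. It differs from compound 3 by cyclopropyl in place of 4-methoxyphenyl on an aromatic carbon. For the measured compounds named here, the steps that bear on this are the three already described, in which a large aromatic group, a small silicon-bearing group and a sulfonamide-bearing group were exchanged at the same place, and none of them moved the number beyond the scatter. The expected step is therefore a 1.2-fold lower number from compound 3 to compound 4 (0.07 log units; within the scatter), that is, no change beyond the scatter. Compound 4 is expected to give about 24000 nM in this assay, with a range from 10000 nM to 60000 nM.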

Compound 4, half-maximal inhibitory concentration: 43900 nM
For compound 4 the middle estimate is 1.8-fold (0.26 log units) below the measured one, within the range that was stated.
By their numbers in this assay, from the lowest: compounds 1, 2, 3 and 4 (each within the scatter of the next, the first and the last beyond it).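

In this assay, for the compounds shown here, no exchange at this aromatic carbon had moved the number beyond the scatter, but cyclopropyl gives the first steps that do, though both are modest: a 2.3-fold higher number from compound 2 to compound 4 (0.36 log units; beyond the scatter) and a 2.6-fold higher number from compound 1 to compound 4 (0.42 log units; beyond the scatter). The direct exchange for 4-methoxyphenyl, a 1.6-fold higher number from compound 3 to compound 4 (0.19 log units; within the scatter), stays within the scatter, so compound 3 and compound 4 cannot be told apart, and the position tolerates only a limited spread that becomes visible between the ends of the series. Few heavy atoms alone do not set the number, since compound 2 also carries a small group and yet lies beyond the scatter from compound 4, and nothing measured here gives a reason for these differences.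

As far as these compounds go, it remains open whether an amine, a carboxylic acid or a longer carbon chain on this aromatic carbon would give a number clearly apart from that of compound 1, in either direction. From the compounds shown here alone, all four compounds keep the shared core, so how much the number depends on the rest of the molecule, compared with this one position, also remains open.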